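Shortening the Diethylamino Chain: Compound 3 in Prospect

The source may report more compounds than this note shows. Statements on the series, on what has been measured and on what is new or still open speak of the compounds shown alone.

Measured so far in a functional assay on HT-29 cells (Homo sapiens) for cytotoxicity, read by MTT assay, with a stated time of 72 h; a lower number here means a stronger inhibitor, a higher number a weaker inhibitor:
- compound 1 `CCN(CC)CCCNc1nc(-c2ccc(NC(=O)Nc3ccccc3)cc2)nc2c(Cl)c(Cl)sc12`: 820 nM
- compound 2 `CCN(CC)CCCNc1nc(-c2ccc(NC(=O)Nc3ccccc3Cl)cc2)nc2c(Cl)c(Cl)sc12`: 410 nM

Within the data shown here, the single measured step, a 2.0-fold lower number from compound 1 to compound 2 (0.30 log units; within the scatter), comes from a chloro in place of hydrogen on an aromatic carbon. Compound 2 stands at the smaller of the two numbers, but the gap to compound 1 is within the scatter, so the two cannot be told apart on this evidence.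

Compound 3 `CCN(CC)CCNc1nc(-c2ccc(NC(=O)Nc3ccccc3Cl)cc2)nc2c(Cl)c(Cl)sc12` differs from compound 2 by diethylamino in place of (diethylamino)methyl on a saturated chain carbon, two bonds along the chain from a nitrogen on an aromatic ring. Among the measured compounds shown here, no measured step bears on this change: the only step on record alters a different part of the molecule. With nothing to point either way, no shift beyond the scatter is expected in this assay. Compound 3 is therefore estimated at 500 nM, within a range of 150 nM to 1700 nM. The expected step is a 1.2-fold higher number from compound 2 to compound 3 (0.09 log units; within the scatter).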

Compound 3, half-maximal inhibitory concentration: 550 nM
For compound 3 the middle estimate is 1.1-fold (0.04 log units) below the measured one, within the range that was stated.
By their numbers in this assay, from the lowest: compounds 2, 3 and 1 (each within the scatter of the next).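

In this assay, diethylamino in place of (diethylamino)methyl at this saturated chain carbon gives a 1.3-fold higher number from compound 2 to compound 3 (0.13 log units; within the scatter) and so no readable difference. Among these compounds, the earlier step concerned only a chloro on an aromatic carbon, so this is the first reading on the chain itself: with that chloro in place, the (3-(diethylamino)propyl)amino and (2-(diethylamino)ethyl)amino chains cannot be told apart in this assay. Nothing available explains this result.

The compounds shown leave open whether a longer chain, or a dimethylamino group or a carboxylic acid in place of the diethylamino end, would give a number beyond the scatter. They also leave open whether the (2-(diethylamino)ethyl)amino chain would read the same without the chloro that separates compound 2 from compound 1.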